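The compounds below may be only part of what the source reports. "The series", "measured", "known", "first", "only" and "open" are said of these compounds alone.

Within the data shown here, compound 3 `O=C(Nc1cccc(-c2oc3cc(-c4ccc(F)cc4)ccc3c(=O)c2O)c1)c1cnc(Cl)nc1Cl` is the one member of this small set whose result in a functional assay on A549 cells (Homo sapiens) for antiproliferative activity, read by CCK-8 assay, with a stated time of 72 h (on this read-out higher numbers stand for weaker inhibition and lower numbers for stronger inhibition), is only a limit: compound 3 gives > 100000 nM, which is the limit noted in the limit of > 100000 nM in this assay, at which 1 of the 3 values shown sits. Its two relatives carry an aromatic ring of carbon only on the same carbonyl carbon. In this assay compound 1 `O=C(Nc1cccc(-c2oc3cc(-c4ccc(F)cc4)ccc3c(=O)c2O)c1)c1ccc(C(F)(F)F)cc1` gives 19400 nM, and compound 2 `Cc1cc(C)cc(C(=O)Nc2cccc(-c3oc4cc(-c5ccc(F)cc5)ccc4c(=O)c3O)c2)c1` gives 3740 nM; between them lies a 5.2-fold lower number from compound 1 to compound 2 (0.71 log units; beyond the scatter). Both steps toward compound 3, an at least 5.1-fold higher number from compound 1 to compound 3 (0.71 log units; beyond the scatter) and an at least 26-fold higher number from compound 2 to compound 3 (1.42 log units; beyond the scatter), raised the number. Compound 4 `O=C(Nc1cccc(-c2oc3cc(-c4ccc(F)cc4)ccc3c(=O)c2O)c1)c1ccc(-c2ccccc2)cc1` differs from compound 3 by 4-phenylphenyl in place of 2,4-dichloropyrimidin-5-yl on a carbonyl carbon. Reversing that kind of change is expected to lower the number, and the step of an at least 10-fold lower number from compound 3 to compound 4 (1.00 log units; beyond the scatter) is the estimate. Compound 4 is therefore expected at 10000 nM, with a range from 2500 nM to 40000 nM.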

Compound 4, half-maximal inhibitory concentration: > 100000 nM
Compound 4: only a limit was reported (the forecaster's own chance of this, stated with the estimate: 15%); at least 10-fold (1.00 log units) between middle value and limit.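

Compound 4 shows that an aromatic group of carbon only on this carbonyl carbon does not ensure a readable result, which compounds 1 and 2 had suggested. In this assay, 4-phenylphenyl falls behind both relatives, with an at least 26-fold higher number from compound 2 to compound 4 (1.42 log units; beyond the scatter) and an at least 5.1-fold higher number from compound 1 to compound 4 (0.71 log units; beyond the scatter). The result for compound 4 is a limit, not a number, as is that for compound 3, so the step between them cannot be read: the limit of > 100000 nM in this assay, at which 2 of the 4 values shown sit.

On these data alone, how compound 3 and compound 4 rank against each other stays open. So does whether a phenyl ring carrying an amine or a carboxylic acid on this carbonyl carbon would give a readable number.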